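The source may report more compounds than this note shows. Statements on the series, on what has been measured and on what is new or still open speak of the compounds shown alone.

Compound 1 `CCOC(=O)c1oc2ccc(NS(=O)(=O)c3ccccc3Cl)cc2c1C`: in a functional assay on MDA-MB-231 cells (Homo sapiens) for antiproliferative activity, read by MTT assay, with a stated time of 72 h (a lower number here means a stronger inhibitor, a higher number a weaker inhibitor), compound 1 gives > 200000 nM, which is a limit of the assay and not a number.
Compound 2 `CCOC(=O)c1oc2ccc(NS(=O)(=O)c3cccc(C(F)(F)F)c3)cc2c1C`: compound 2 gives 30200 nM.
Compound 3 `CCOC(=O)c1oc2ccc(NS(=O)(=O)c3ccc([N+](=O)[O-])cc3)cc2c1C`: compound 3 gives 33100 nM.
Compound 4 `CCOC(=O)c1oc2ccc(NS(=O)(=O)c3cccc([N+](=O)[O-])c3)cc2c1C`: not yet measured.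

Of the two numbers in hand, compound 3 holds the higher one, yet its gap to compound 2 lies within the scatter, so the two cannot be put in order. Compound 1 stands only at a limit. For the measured compounds named here, the single measured step that reaches compound 3 is an at least 6.0-fold lower number from compound 1 to compound 3 (0.78 log units; beyond the scatter), and its true size is bounded only by the limit of > 200000 nM in this assay, at which 1 of the 3 values shown sits.

Compound 4 is obtained from compound 3 by 3-nitrophenyl in place of 4-nitrophenyl on a sulfonyl sulfur. Going by the values given here, no measured step shifts a group from one place on the phenyl ring to another, so there is no direct precedent for this change. The nearest guide is compound 2, which carries a different substituent on the same ring and gives a value within the scatter of compound 3. On that basis the move is expected to be a 1.1-fold lower number from compound 3 to compound 4 (0.04 log units; within the scatter), no step beyond the scatter in either direction. Compound 4 is therefore estimated at 30000 nM, within a range from 12000 nM to 80000 nM.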

Compound 4, half-maximal inhibitory concentration: 59900 nM
Estimate against measurement, compound 4: 2.0-fold (0.30 log units) below; the measured number falls inside the stated range.
By their numbers in this assay, from the lowest: compounds 2, 3 and 4 (each within the scatter of the next). At a limit, above all of these: compound 1.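

Shifting the nitro group on the sulfonyl-bound ring gives the first measured move of a group around that ring: a 1.8-fold higher number from compound 3 to compound 4 (0.26 log units; within the scatter), so 4-nitrophenyl and 3-nitrophenyl cannot be told apart here. Exchanging the group itself also leaves the result within the scatter, with nitro in place of trifluoromethyl on an aromatic carbon giving a 2.0-fold higher number from compound 2 to compound 4 (0.30 log units; within the scatter). With 3-nitrophenyl in place of 2-chlorophenyl the result is an at least 3.3-fold lower number from compound 1 to compound 4 (0.52 log units; beyond the scatter), which lies beyond the scatter, but its true size stays unknown because compound 1 stands at a limit of the assay and not a number: the limit of > 200000 nM in this assay, at which 1 of the 4 values shown sits.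

In the compounds shown, the identity of the substituent on this ring and its place change together between compound 1 and the others, so the two effects cannot be separated. From the compounds shown here alone, it also stays open whether an amine on this ring, or a carboxylic acid in place of the ethyl ester, would shift the number beyond the scatter.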